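A few compounds are considered here, and "the series" means these few. Any claim that something is new, unique, unknown or untested is made for them only; others in the source may bear on it.

Measured compounds: compound 1 `CC(=O)/C(=N\c1cccc(C)c1)NNc1ccccc1C` with 526 nM; compound 2 `CC(=O)/C(=N\c1ccccc1)NNc1ccccc1C(F)(F)F` with 2260 nM; compound 3 `CC(=O)/C(=N\c1ccccc1Cl)NNc1ccccc1C(F)(F)F` with > 10000 nM.

In an assay on isolated protein for binding affinity to corticotropin-releasing factor receptor 1 (Homo sapiens) (on this read-out lower numbers stand for stronger inhibition and higher numbers for weaker inhibition), compound 3 gives > 10000 nM, which is a limit of the assay rather than a number. It sits at the limit of > 10000 nM in this assay, at which 1 of the 3 values shown sits. Compound 4 `CC(=O)/C(=N\c1cccc(C)c1)NNc1ccccc1C(F)(F)F` carries 3-methylphenyl in place of 2-chlorophenyl on a double-bonded nitrogen. Going by the values given here, the one measured step nearby, an at least 4.4-fold higher number from compound 2 to compound 3 (0.64 log units; beyond the scatter), is undone here, so the chloro is removed; the methyl added has no measured counterpart with this trifluoromethyl partner. Compound 1 gives 526 nM and compound 2 gives 2260 nM in this assay, and they differ in two places, so they set only a rough frame. Compound 4 is therefore expected to land near compound 2, with a step of an at least 6.6-fold lower number from compound 3 to compound 4 (0.82 log units; beyond the scatter), estimated at 1500 nM within 400 nM to 6000 nM.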

Compound 4, inhibition constant: 1420 nM
Beside the measured number, compound 4's estimate is 1.1-fold (0.02 log units) above it, within the range that was stated.
By their numbers in this assay, from the lowest: compound 1; then compounds 4 and 2 (each within the scatter of the next). At a limit, above all of these: compound 3.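

In this assay, moving from the 2-chlorophenyl to the 3-methylphenyl on the double-bonded nitrogen restores measurable binding with the trifluoromethyl partner (an at least 7.0-fold lower number from compound 3 to compound 4 (0.84 log units; beyond the scatter)). The added methyl itself gives no clear change (a 1.6-fold lower number from compound 2 to compound 4 (0.20 log units; within the scatter)), whereas trifluoromethyl in place of methyl on an aromatic carbon gives a modest one (a 2.7-fold higher number from compound 1 to compound 4 (0.43 log units; beyond the scatter)). The value of compound 3 is a limit of the assay, not a number: the limit of > 10000 nM in this assay, at which 1 of the 4 values shown sits.

Going by these compounds, whether a methoxy group or a longer chain such as ethyl could stand in place of the methyl of the 3-methylphenyl remains open. So does what an amine or a carboxylic acid would do there.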